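Benzylsulfonyl in Place of Hydroxyethyl on the Aryl Ether Oxygen

The source may report more compounds than this note shows. Statements on the series, on what has been measured and on what is new or still open speak of the compounds shown alone.

Measured compounds:
compound 1 `C=CCOc1cc(/C=C/C(=O)c2ccc(OC)c3c2OC(C)(C)C=C3)ccc1OC` gives > 10000 nM
compound 2 `COc1ccc(/C=C/C(=O)c2ccc(OC)c3c2OC(C)(C)C=C3)cc1OCCO` gives > 10000 nM
compound 3 `C=CC(=O)Oc1cc(/C=C/C(=O)c2ccc(OC)c3c2OC(C)(C)C=C3)ccc1OC` gives 160 nM

In a functional assay on HepG2 cells (Homo sapiens) for cytotoxicity, read by MTT assay (on this read-out higher numbers stand for weaker inhibition and lower numbers for stronger inhibition), compound 2 reaches only a limit, > 10000 nM, not a number. Compound 1 likewise sits at a limit, > 10000 nM. Among the measured compounds shown here, compound 3 is the only one with a measured number, 160 nM; this follows from the limit of > 10000 nM in this assay, at which 2 of the 3 values shown sit.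

The unmeasured compound 4 `COc1ccc(/C=C/C(=O)c2ccc(OC)c3c2OC(C)(C)C=C3)cc1OS(=O)(=O)Cc1ccccc1` differs from compound 2 by benzylsulfonyl in place of 2-hydroxyethyl on an oxygen on an aromatic ring.

Two measured steps change the same oxygen. The step of an at least 62-fold lower number from compound 2 to compound 3 (1.79 log units; beyond the scatter) and the step of an at least 62-fold lower number from compound 1 to compound 3 (1.79 log units; beyond the scatter) both show that exchanging the chain on this oxygen can lower the number strongly. The group entering in compound 4 is benzylsulfonyl, not vinylcarbonyl, so those steps guide only loosely. A lower number is still expected for compound 4, around 3000 nM, within 400 nM to 15000 nM, meaning an expected step of an at least 3.3-fold lower number from compound 2 to compound 4 (0.52 log units; beyond the scatter), with a real chance that compound 4 again returns only a limit.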

Compound 4, half-maximal inhibitory concentration: > 10000 nM
Compound 4: no number, only a limit; the forecaster's own chance of this, stated with the estimate: 40%; middle value at least 3.3-fold (0.52 log units) away from the limit.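

In this assay, putting benzylsulfonyl in place of vinylcarbonyl on the oxygen on the aromatic ring gives an at least 62-fold higher number from compound 3 to compound 4 (1.79 log units; beyond the scatter). Allyl and 2-hydroxyethyl had already failed to give a measured number at this oxygen, and benzylsulfonyl, with its sulfur and its aromatic ring, now joins them, so compound 3 remains the only one of the four with a measured number. The steps linking compound 4 with compound 1 and compound 2 cannot be read, because all three stand at the same limit: the limit of > 10000 nM in this assay, at which 3 of the 4 values shown sit.

On these data alone, how far these three compounds differ beyond that limit stays open. Also open, as far as these compounds go, is whether the low number of compound 3 needs the whole vinylcarbonyl group or only its carbonyl, a question that an acetyl group on the same oxygen would address.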